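This account rests on a few compounds, and the source may have more. Where it says the series, first, only, none or still open, it means among the compounds named here.

Measured so far:
Compound 1 `CN(C)c1ccc(/C=C2\CCC/C(=C\c3ccccc3[N+](=O)[O-])C2=O)cc1` gives 4.86 in a physicochemical assay for lipophilicity; on this read-out lower numbers stand for lower lipophilicity and higher numbers for higher lipophilicity.
Compound 2 `COc1cc(/C=C2\CCC/C(=C\c3cccc([N+](=O)[O-])c3)C2=O)cc(OC)c1OC` gives 5.06 in this assay.

Of these two numbers, compound 1 has the lower one, but the gap to compound 2 lies within the usual scatter of repeated measurements of this kind, so the two cannot really be told apart. Compound 3 `O=C1/C(=C/c2ccc(F)cc2)CCC/C1=C\c1ccccc1[N+](=O)[O-]` has not yet been measured. It differs from compound 1 in one place: fluoro in place of dimethylamino on an aromatic carbon, para to a large group. For the measured compounds named here, no pair of measured compounds shows this change, so there is no direct precedent for it in this assay. Starting from compound 1 at 4.86, the step is expected to be a number 0.04 log units higher from compound 1 to compound 3 (within the scatter), which is none beyond the scatter. Compound 3 is therefore estimated to come in at 4.9, within a range from 4.4 to 5.4.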

Compound 3, partition coefficient: 4.86
Compound 3: the middle estimate sits 0.04 log units above what was measured, and the stated range covers the measured number.
By their numbers in this assay, from the lowest: compounds 1, 3 and 2 (each within the scatter of the next).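

Replacing dimethylamino with fluoro on this aromatic carbon, para to a large group, gives in this assay no change at the digits printed from compound 1 to compound 3 (within the scatter). For the compounds shown here, this is the first direct look at this position: here a group of 3 heavy atoms, carbon and nitrogen, gives way to a single fluorine and the read-out stays within the scatter. The two groups cannot be told apart in this one pair, and nothing shown here accounts for that.

What the compounds shown leave open is whether other groups at this position, such as a carboxylic acid or a longer carbon chain, would also stay within the scatter. Going by these compounds, whether the same exchange would give a similar result on a different core also remains open, since one pair sets no general pattern.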